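Acid-terminated diaryl ethers at the assay ceiling

A few compounds are considered here, and "the series" means these few. Any claim that something is new, unique, unknown or untested is made for them only; others in the source may bear on it.

Compound 1 `Cc1cccc(OCCCOc2ccc(CCC(=O)O)cc2)c1C` in an assay for inhibition of Polyunsaturated fatty acid 5-lipoxygenase (Homo sapiens), read by HPLC, with a stated time of 10 min (on this read-out lower numbers stand for stronger inhibition and higher numbers for weaker inhibition), gives > 10000 nM, which is a limit of the assay and not a number.
Compound 2 `CCCCC(Sc1ccc(OCCCOc2cccc3c2CCCC3)cc1)C(=O)OCC` in this assay gives > 10000 nM, likewise a limit.
Compound 3 `CCCCC(Sc1ccc(OCCCOc2ccc3ncccc3c2)cc1)C(=O)O` in this assay gives > 10000 nM, again a limit.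

Compound 1 therefore stands nowhere on a numerical scale: all that is known is the limit of > 10000 nM in this assay, at which 3 of the 3 values shown sit, and the two further compounds sit at the same ceiling. No pair of these compounds differs in a single place, so no measured step exists in the series and no direction of change can be read from it.

Compound 4 `Cc1cccc(OCCCOc2ccc(SCC(=O)O)cc2)c1C` is the untested member. It differs from compound 1 by (carboxymethyl)sulfanyl in place of 2-carboxyethyl on an aromatic carbon, para to a large group, with the rest of the shared core unchanged. With every measured compound at the ceiling, the step is expected to be none beyond the scatter, and a step that the limit leaves unreadable from compound 1 to compound 4 is the expected step that this estimate means. Compound 4 is expected to give 20000 nM, with a range from 5000 nM to 100000 nM, most likely reported again only as a limit.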

Compound 4, half-maximal inhibitory concentration: > 10000 nM
Compound 4: only a limit was reported; the forecaster's own chance of this, stated with the estimate: 80%; the middle value is on the limit's open side.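

Compound 4 gives > 10000 nM in this assay, which is a limit of the assay and not a number. For the compounds shown here, no step from compound 1 to compound 4 can be read, since both compounds stand only at a limit: the limit of > 10000 nM in this assay, at which 4 of the 4 values shown sit.

The compounds shown leave open whether (carboxymethyl)sulfanyl and 2-carboxyethyl differ at all on this read-out.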